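A few compounds are considered here, and "the series" means these few. Any claim that something is new, unique, unknown or untested is made for them only; others in the source may bear on it.

The measured compounds are:
compound 1, `COc1ccc(-c2cc(/C=C/C(=O)c3ccc(N)cc3)[nH]n2)cc1`, 36%;
compound 2, `COc1ccc(C(=O)/C=C/c2cc(-c3cc(OC)c(OC)c(OC)c3)n[nH]2)cc1OC`, 2%;
compound 3, `COc1ccc(-c2cc(/C=C/C(=O)c3ccc(N)cc3)[nH]n2)cc1OC`, 59%.

All three were tested in a functional assay on RPMI-8226 cells (Homo sapiens) for cytotoxicity, read by sulforhodamine B assay, with a stated time of 48 h, tested at 1 uM; on this read-out higher numbers stand for a weaker effect at the one concentration tested and lower numbers for a stronger effect. Compound 2 gives the lowest number of the three, so its effect at this concentration is the strongest; its gap to compound 1 and to compound 3 lies beyond the scatter in each case. Compound 1 and compound 3 differ in one place: methoxy in place of hydrogen on an aromatic carbon. In this assay this gives a number 23 percentage points higher from compound 1 to compound 3 (beyond the scatter), that is, a weaker effect. How the core of compound 2 differs from the core of compound 1 is not broken down here.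

Compound 4, `COc1cc(C(=O)/C=C/c2cc(-c3cc(OC)c(OC)c(OC)c3)n[nH]2)cc(OC)c1OC`, has not yet been measured. It arises from compound 2 by the same kind of change: methoxy in place of hydrogen on an aromatic carbon. The surroundings of the place are not identical, since in compound 4 the entering group also stands meta to a methoxy group, which is not so for compound 3. A smaller rise is expected than a number 23 percentage points higher from compound 1 to compound 3 (beyond the scatter), namely a number 6 percentage points higher from compound 2 to compound 4 (within the scatter), because compound 2 already sits at 2% and has little room to fall. Compound 4 is therefore expected to give 8%, between 1% and 30%.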

Compound 4, a percentage reported as activity, at one concentration (the size of the read-out at that concentration, not a potency): 17%
Estimate against measurement, compound 4: 9 percentage points below, and the stated range covers the measured number.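

In this assay, methoxy in place of hydrogen on an aromatic carbon again weakens the effect, giving a number 15 percentage points higher from compound 2 to compound 4 (beyond the scatter), so the direction seen on the core of compound 1 carries over to the core of compound 2. Among these compounds, the size of the step cannot be told apart between the two cores: the same change on two cores in this assay, a number 23 percentage points higher (beyond the scatter) from compound 1 to compound 3 and a number 15 percentage points higher (beyond the scatter) from compound 2 to compound 4, 8 percentage points apart, within the scatter of two such steps This rests on only two pairs, read at a single concentration, and it does not show that the change would act in the same way on any other core, or at another place on the ring; in compound 4 the methoxy group enters ortho to a methoxy group and meta to a methoxy group.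

The compounds shown leave open whether a hydroxyl group, a chlorine atom or a longer chain such as ethoxy at that place would give a different result from methoxy. They also leave open how the core of compound 2 would behave with an amine on its ring, as compound 1 and compound 3 carry.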